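The compounds below may be only part of what the source reports. "The series", "measured", "known", "first", "only" and "open" are said of these compounds alone.

Compound 1, `c1cncc(N2CCCNCCC2)c1`, gives 78% in an assay on HEK293 cells with Neuronal acetylcholine receptor; alpha4/beta2 (Homo sapiens) as the target, read by FLIPR and calcium flux; a higher number here means a larger maximal response, a lower number a smaller maximal response.
Compound 2, `C/C=C\Oc1cncc(N2CCCNCC2)c1`, gives 45% in this assay.
Compound 3, `c1ccc2ncc(N3CCCNCC3)cc2c1`, gives 33% in this assay.

Among these three, compound 1 stands highest in this assay; compound 2 sits beyond the usual scatter below it, and compound 3 lies further below still. Compound 4, `Brc1cncc(N2CCCNCCC2)c1`, has not yet been measured. It differs from compound 1 in one place: bromo in place of hydrogen on an aromatic carbon. Within the data shown here, no measured pair shows this same change, so the data give no direct guide to its effect. For compound 4 a small downward step is expected, a number 13 percentage points lower from compound 1 to compound 4 (beyond the scatter), one that may not exceed the usual scatter. Compound 4 is therefore estimated to reach about 65% in this assay, within a range from 40% to 90%.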

Compound 4, largest response reached (reported as efficacy), in percent of the reference or control that the assay uses: 73%
The estimate for compound 4 lay 8 percentage points below the measured number, and the stated range covers the measured number.
By their numbers in this assay, from the lowest: compound 3; then compound 2; then compounds 4 and 1 (each within the scatter of the next).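

Among these compounds, measured in this assay, bromo in place of hydrogen on this aromatic carbon, two atoms from the ring nitrogen, gives a number 5 percentage points lower from compound 1 to compound 4 (within the scatter) as the first step that can be read at one place. The maximal response of the core of compound 1 therefore tolerates this single bromine atom here. Nothing available explains this result. Open, from the compounds shown here alone, is whether another group on this carbon, such as an amine, a nitrile or a longer carbon chain, would be tolerated as well.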